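Adding iodo to the phenyl ring of compound 3

The source may hold more compounds than are shown below. What is called first, only, known or untested is meant among the compounds shown, and "the series" means these compounds.

In a functional assay on ECa-109 cells for inhibition, with ECa-109 cell line (Homo sapiens) as the target, read by sulforhodamine B assay (a higher number here means a weaker inhibitor, a lower number a stronger inhibitor), compound 1 `O=C1C=C(NC2CCCC2)C(=O)c2c1nc1n2[C@H]2OC[C@@H](O)[C@H]2OC1`, with a cyclopentyl on the amine nitrogen, gives > 16000 nM, which is a limit of the assay and not a number. Compound 2 `CCOc1ccccc1NC1=CC(=O)c2nc3n(c2C1=O)[C@H]1OC[C@@H](O)[C@H]1OC3` carries a 2-ethoxyphenyl there and gives 4630 nM, while compound 3 `O=C1C=C(Nc2ccccc2)C(=O)c2c1nc1n2[C@H]2OC[C@@H](O)[C@H]2OC1` carries a plain phenyl and gives 4970 nM. Compound 3 therefore stands level with its nearest neighbour, as a 1.1-fold higher number from compound 2 to compound 3 (0.03 log units; within the scatter) shows. Replacing the cyclopentyl with an aromatic ring gave clear gains: an at least 3.4-fold lower number from compound 1 to compound 2 (0.53 log units; beyond the scatter) and an at least 3.2-fold lower number from compound 1 to compound 3 (0.50 log units; beyond the scatter).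

Compound 4 `O=C1C=C(Nc2ccc(I)cc2)C(=O)c2c1nc1n2[C@H]2OC[C@@H](O)[C@H]2OC1` makes one further change, iodo in place of hydrogen on an aromatic carbon, para to a large group, which turns phenyl into 4-iodophenyl. The cyclopentyl steps swap the whole group, so they say little about this smaller edit. The closest guide is the ethoxy comparison, a 1.1-fold higher number from compound 2 to compound 3 (0.03 log units; within the scatter), although that group is different and sits elsewhere on the ring. A large shift therefore seems unlikely, and no change beyond the scatter is expected. The estimated step in this assay is a 1.4-fold lower number from compound 3 to compound 4 (0.15 log units; within the scatter). For compound 4 the expected value is 3500 nM, with an estimated range from 1300 nM to 10000 nM.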

Compound 4, half-maximal inhibitory concentration: 2300 nM
The estimate for compound 4 lay 1.5-fold (0.18 log units) above the measured number; measured number inside the range.
By their numbers in this assay, from the lowest: compounds 4, 2 and 3 (each within the scatter of the next, the first and the last beyond it). At a limit, above all of these: compound 1.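

On the phenyl ring of compound 3, a single iodo para to a large group gives a change beyond the scatter in this assay, a 2.2-fold lower number from compound 3 to compound 4 (0.33 log units; beyond the scatter), which shows that this ring can respond to a one-atom edit, something the ethoxy comparison did not reveal; yet 4-iodophenyl and 2-ethoxyphenyl still cannot be told apart, as a 2.0-fold lower number from compound 2 to compound 4 (0.30 log units; within the scatter) shows. Set against the cyclopentyl group, the 4-iodophenyl group gives an at least 6.9-fold lower number from compound 1 to compound 4 (0.84 log units; beyond the scatter), which adds a third aromatic example to the two already seen, each of them with a lower number than the cyclopentyl compound. The value of compound 1 is a limit of the assay and not a number: the limit of > 16000 nM in this assay, at which 1 of the 4 values shown sits.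

From the compounds shown here alone, what stays open is whether this step belongs to iodo itself, or whether fluoro, chloro, bromo or a methyl group in the same place would give a similar one, and whether iodo elsewhere on the ring would do the same. Equally open, going by these compounds, is how a carboxylic acid or an amine at this place would read, and the values shown give no cause for the step.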